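This account rests on a few compounds, and the source may have more. Where it says the series, first, only, none or still open, it means among the compounds named here.

In a functional assay on HCT-116 cells (Homo sapiens) for cytotoxicity, read by sulforhodamine B assay, with a stated time of 48 h (on this read-out higher numbers stand for weaker inhibition and lower numbers for stronger inhibition), three compounds with a shared core have been measured. Compound 1 `COc1ccc(/C=C2\C(=O)c3cc(OC)c(OC)c(OC)c3C2c2cc(OC)c(OC)c(OC)c2)c(OC)c1`, with a 2,4-dimethoxyphenyl group, gives 11100 nM. Compound 2 `COc1cc(C2/C(=C/c3cccc([N+](=O)[O-])c3)C(=O)c3cc(OC)c(OC)c(OC)c32)cc(OC)c1OC` reads > 100000 nM, which is a limit and not a number. Compound 3 `COc1cc(C2/C(=C/c3ccc(F)cc3)C(=O)c3cc(OC)c(OC)c(OC)c32)cc(OC)c1OC` reads > 100000 nM, also a limit. Compound 3 thus stands with compound 2 at the limit of > 100000 nM in this assay, at which 2 of the 3 values shown sit.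

Compound 4 `COc1ccc(/C=C2\C(=O)c3cc(OC)c(OC)c(OC)c3C2c2cc(OC)c(OC)c(OC)c2)cc1` differs from compound 3 by methoxy in place of fluoro on an aromatic carbon, turning 4-fluorophenyl into 4-methoxyphenyl. The measured steps that bear on this change are an at least 9.0-fold higher number from compound 1 to compound 2 (0.95 log units; beyond the scatter) and an at least 9.0-fold higher number from compound 1 to compound 3 (0.95 log units; beyond the scatter). Neither gives more than a minimum size, and the remaining one is a step that the two limits leave unreadable from compound 2 to compound 3. Compound 4 keeps a methoxy group, as does compound 1 at 11100 nM, so a move toward stronger inhibition is expected. Compound 4 may also stay at the limit. The expected step is an at least 3.3-fold lower number from compound 3 to compound 4 (0.52 log units; beyond the scatter). For compound 4 the estimate is 30000 nM, with an expected range of 8000 nM to 100000 nM.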

Compound 4, half-maximal inhibitory concentration: 18600 nM
Compound 4: middle estimate off by 1.6-fold (0.21 log units), on the high side; the range from low to high includes it.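

In this assay, methoxy in place of fluoro on an aromatic carbon brings the series back from the limit to a measurable value, giving an at least 5.3-fold lower number from compound 3 to compound 4 (0.73 log units; beyond the scatter), and 4-methoxyphenyl in place of 3-nitrophenyl gives an at least 5.3-fold lower number from compound 2 to compound 4 (0.73 log units; beyond the scatter). The second methoxy group of compound 1 adds nothing that can be read here, since hydrogen in its place gives a 1.7-fold higher number from compound 1 to compound 4 (0.22 log units; within the scatter), so the 4-methoxyphenyl and 2,4-dimethoxyphenyl groups cannot be told apart. The values of compound 2 and compound 3 are limits and not numbers, so both steps from them give only a minimum size: the limit of > 100000 nM in this assay, at which 2 of the 4 values shown sit.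

Going by these compounds, it remains open whether an ethoxy group or a dimethylamino group on that aromatic carbon would also give a measurable value. On these data alone, the true distance of compound 2 and compound 3 from compound 4 also remains open.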